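From Benzoyl to 1-Phenylethyl on an Amine Nitrogen

A few compounds are considered here, and "the series" means these few. Any claim that something is new, unique, unknown or untested is made for them only; others in the source may bear on it.

In an ADME assay on L6 cells (Rattus norvegicus) for cytotoxicity (on this read-out lower numbers stand for stronger inhibition and higher numbers for weaker inhibition), compound 1 (`C/C=C(/C)C(=O)OC(C)c1cc2c(cc1OC)OC(C)(C)C=C2`) gives 139000 nM and compound 2 (`COc1cc2c(cc1C(C)OC/C=C/c1ccccc1)C=CC(C)(C)O2`) gives 64400 nM. Compound 3 (`COc1cc2c(cc1C(C)NC(=O)c1ccccc1)C=CC(C)(C)O2`) gives 34800 nM, which is within the usual scatter of compound 2 and clearly lower than compound 1. Compound 4 (`COc1cc2c(cc1C(C)N[C@@H](C)c1ccccc1)C=CC(C)(C)O2`) carries 1-phenylethyl in place of benzoyl on an amine nitrogen. Going by the values given here, no measured pair shows this swap, so any forecast is uncertain. The three measured numbers lie fairly close together, so no step beyond the scatter is expected, though the number may drift slightly lower. The expected step is a 1.3-fold lower number from compound 3 to compound 4 (0.13 log units; within the scatter). For compound 4 the estimated value is 26000 nM, with an expected range from 9000 nM to 75000 nM.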

Compound 4, half-maximal inhibitory concentration: 16500 nM
Compound 4: middle estimate off by 1.6-fold (0.20 log units), on the high side; low and high end bracket the measured number.
By their numbers in this assay, from the lowest: compound 4; then compounds 3 and 2 (each within the scatter of the next); then compound 1.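

In this assay, going by these compounds alone, 1-phenylethyl in place of benzoyl on this nitrogen gives a 2.1-fold lower number from compound 3 to compound 4 (0.32 log units; beyond the scatter), the first step here that isolates a single change. The benzoyl carbonyl is therefore not required to keep the number this low, and the modest step moves towards stronger inhibition. No available measurement explains this shift.

As far as these compounds go, it remains open whether the opposite stereocentre of 1-phenylethyl gives a similar number. A plain benzyl group or a longer chain on the same nitrogen could also move it either way.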